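From 4-methylbenzyl to 4-methylphenyl in compound 4

A few compounds are considered here, and "the series" means these few. Any claim that something is new, unique, unknown or untested is made for them only; others in the source may bear on it.

In a functional assay on MDA-MB-231 cells (Homo sapiens) for inhibition, read by CCK-8 assay, with a stated time of 48 h (a higher number here means a weaker inhibitor of growth, a lower number a stronger inhibitor of growth), compound 1 `Cc1ccccc1Nc1nc(Nc2ccccc2)ncc1Cl` gives > 100000 nM, which is a limit of the assay. Compound 2 `Cc1ccccc1Nc1nc(Nc2ccc(N3CCCCC3)cc2)ncc1Cl` gives 19900 nM. Compound 3 `Cc1ccc(CNc2nc(Nc3ccc(N4CCN(C)CC4)cn3)ncc2Cl)cc1` gives 18600 nM, a number within the usual scatter of that of compound 2. Compound 4 `Cc1ccc(Nc2nc(Nc3ccc(N4CCN(C)CC4)cn3)ncc2Cl)cc1` is still unmeasured, and it carries 4-methylphenyl in place of 4-methylbenzyl on a nitrogen on an aromatic ring. Going by the values given here, the only measured step, an at least 5.0-fold lower number from compound 1 to compound 2 (0.70 log units; beyond the scatter), came with piperidin-1-yl in place of hydrogen on an aromatic carbon. That is a different change, so it sets no size here, and no step beyond the scatter is expected in this assay. The expected step is a 1.2-fold lower number from compound 3 to compound 4 (0.09 log units; within the scatter). For compound 4 the estimated value is 15000 nM, with an expected range of 4000 nM to 50000 nM.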

Compound 4, concentration for 50% growth inhibition: 4030 nM
Beside the measured number, compound 4's estimate is 3.7-fold (0.57 log units) above it, within the range that was stated.
By their numbers in this assay, from the lowest: compound 4; then compounds 3 and 2 (each within the scatter of the next). At a limit, above all of these: compound 1.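

Swapping 4-methylbenzyl for 4-methylphenyl on this nitrogen gives a 4.6-fold lower number from compound 3 to compound 4 (0.66 log units; beyond the scatter) in this assay and is the first step shown at this position. It shows that the group on this nitrogen can alter growth inhibition on its own, while the rest of the molecule stays fixed. Nothing shown explains why this change has this effect.

This rests on a single pair of compounds. Going by these compounds, how a longer chain such as 2-phenylethyl, a cyclohexyl group or a 4-methoxyphenyl group would behave on this nitrogen remains open.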